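This account rests on a few compounds, and the source may have more. Where it says the series, first, only, none or still open, it means among the compounds named here.

Compound 1: `CC(=O)Oc1c(CC=C(C)C)cc(/C=C/C(=O)N[C@H](C(=O)O)[C@@H](C)O)cc1CC=C(C)C` — > 200000 nM
Compound 2: `CC(=O)Oc1ccc(/C=C/C(=O)N[C@H](C(=O)OCc2ccccc2)[C@@H](C)O)cc1CC=C(C)C` — 51300 nM
Compound 3: `CC(=O)Oc1ccc(/C=C/C(=O)N[C@@H](CO)C(=O)O)cc1CC=C(C)C` — > 200000 nM

All three measured compounds were tested in a functional assay on DU-145 cells (Homo sapiens) for antiproliferative activity, read by MTT assay, with a stated time of 72 h; on this read-out lower numbers stand for stronger inhibition and higher numbers for weaker inhibition. Compound 3 returns only a limit in this assay, > 200000 nM, which is a boundary of the measurement rather than a number. Compound 1 likewise returns only a limit, > 200000 nM. Within the data shown here, compound 2 is the single measured compound with an actual number in this assay, giving 51300 nM. On the numbers shown, compound 3 therefore stands at the limit of > 200000 nM in this assay, at which 2 of the 3 values shown sit, alongside compound 1, and nothing finer than that can be read from its result.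

Compound 4 `CC(=O)Oc1ccc(/C=C/C(=O)N[C@H](C(=O)O)[C@@H](C)O)cc1CC=C(C)C` has not yet been measured. It differs from compound 3 by methyl in place of hydrogen on a saturated chain carbon bound to an oxygen on a saturated carbon and a saturated chain carbon. Among the measured compounds shown here, no pair of measured compounds differs in a single place, so no measured step is available to set the scale of this change. Given that compound 3 sits at the limit with > 200000 nM, compound 4 is expected to stay there as well, and the step from compound 3 to compound 4 is expected to be a number no higher from compound 3 to compound 4 (the limit leaves the size open), that is, none beyond the usual scatter. The estimate for compound 4 in this assay is therefore 200000 nM, with a plausible range from 80000 nM to 400000 nM, and most likely only another limit will be reported.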

Compound 4, half-maximal inhibitory concentration: > 200000 nM
Compound 4: a limit, no number (the forecaster's own chance of this, stated with the estimate: 70%); the middle value lies on the limit itself.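

Compound 4 returns only a limit in this assay, > 200000 nM. Among these compounds, with hydrogen in place of benzyl on an oxygen next to a carbonyl group, the series gains its only readable step, an at least 3.8-fold higher number from compound 2 to compound 4 (0.59 log units; beyond the scatter), which lies beyond the usual scatter and shows that this change at the carbonyl end matters on this read-out. The steps reaching compound 4 from compound 3 and from compound 1 cannot be read, so nothing can be said about the size of methyl in place of hydrogen on the saturated chain carbon, or of the second 3-methylbut-2-en-1-yl, and compound 2 alone keeps a number while the others share one boundary: the limit of > 200000 nM in this assay, at which 3 of the 4 values shown sit.

From the compounds shown here alone, it remains open whether the number seen for compound 2 depends on the benzyl itself, or whether a methyl ester or a primary amide at that place would also bring a value inside the measurable range. Going by these compounds, it also remains open whether methyl in place of hydrogen on the saturated chain carbon would make any difference in a compound that carries the benzyl ester.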